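Bromo on the fused aromatic ring of compound 2

The source may report more compounds than this note shows. Statements on the series, on what has been measured and on what is new or still open speak of the compounds shown alone.

The series shares the core carried by compound 1 `COC(=O)[C@@]1(C)CCC=C2[C@@H]1CC[C@@H](C)[C@]2(C)Cc1c[nH]c2ccccc12`. In a functional assay on HeLa cells (Homo sapiens) for inhibition, read by sulforhodamine B assay, with a stated time of 48 h (a higher number here means a weaker inhibitor of growth, a lower number a stronger inhibitor of growth), compound 1 gives 3600 nM. Compound 2 `COC(=O)[C@@]1(C)CCC=C2[C@@H]1CC[C@@H](C)[C@]2(C)Cc1c(C)[nH]c2ccccc12` adds a methyl on an aromatic carbon; in this assay compound 2 gives 11000 nM, the step being a 3.1-fold higher number from compound 1 to compound 2 (0.49 log units; beyond the scatter). Compound 3 `COC(=O)[C@@]1(C)CCC=C2[C@@H]1CC[C@@H](C)[C@]2(C)Cc1c(C)[nH]c2ccc(F)cc12` carries in addition a fluoro on an aromatic carbon; in this assay compound 3 gives 11000 nM, with no change at the digits printed from compound 2 to compound 3 (within the scatter). Compound 2 thus stands level with compound 3 at the digits printed, the two together forming the high end of the three numbers, and it is set apart from compound 1 only by a 3.1-fold higher number from compound 1 to compound 2 (0.49 log units; beyond the scatter).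

Compound 4 `COC(=O)[C@@]1(C)CCC=C2[C@@H]1CC[C@@H](C)[C@]2(C)Cc1c(C)[nH]c2c(Br)cccc12` differs from compound 2 by bromo in place of hydrogen on an aromatic carbon. Within the data shown here, the one measured step that bears on this change is a halogen entering on an aromatic carbon of the same fused ring, no change at the digits printed from compound 2 to compound 3 (within the scatter), which stayed within the scatter. Among the measured compounds shown here, no step with a bromo exists in the set, and the place on the ring is a different one, so the expectation carries extra uncertainty. The expected step is a 1.1-fold lower number from compound 2 to compound 4 (0.04 log units; within the scatter), that is, no change beyond the scatter. For compound 4 the estimated value in this assay is 10000 nM, with a range from 3500 nM to 30000 nM.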

Compound 4, concentration for 50% growth inhibition: 22000 nM
Estimate against measurement, compound 4: 2.2-fold (0.34 log units) below, within the range that was stated.
By their numbers in this assay, from the lowest: compound 1; then compounds 2, 3 and 4 (each within the scatter of the next).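

In this assay, among these compounds, bromo on an aromatic carbon of the six-membered ring, ortho to a fused ring and meta to a fused ring, gives the first reading at this place (a 2.0-fold higher number from compound 2 to compound 4 (0.30 log units; within the scatter)), and the step does not leave the scatter. With the fluoro step at a different place on the same ring (no change at the digits printed from compound 2 to compound 3 (within the scatter)), two halogen entries on the methyl-bearing compound 2 now read within the scatter, while the methyl step (a 3.1-fold higher number from compound 1 to compound 2 (0.49 log units; beyond the scatter)) remains the only step shown beyond it. Nothing available explains these readings, and the step itself gives no reason for them.

Open, from the compounds shown here alone, is whether an amine or a carboxylic acid on this same aromatic carbon would give a step beyond the scatter in this assay, since only a halogen has been seen on this ring so far. Also open, going by these compounds, is whether bromo at this place would read the same on compound 1, which has hydrogen where compound 2 has its methyl.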